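This account rests on a few compounds, and the source may have more. Where it says the series, first, only, none or still open, it means among the compounds named here.

Of the compounds shown here, three built on one shared core have been measured in an assay on HeLa cells for inhibition of sphingosine-1-phosphate transporter SPNS2 (Mus musculus), read by LC-MS, tested at 2 uM; on this read-out higher numbers stand for more inhibition at the one concentration tested (going by the name of the read-out) and lower numbers for less inhibition. Compound 1 `CCCCCCCCCCc1ccc(-c2noc(CN)n2)cc1` carries an aminomethyl group on an aromatic carbon and gives 62%. Compound 2 `CCCCCCCCCCc1ccc(-c2noc(C3CCNC3)n2)cc1` carries pyrrolidin-3-yl at that place instead and gives 26%. Compound 3 `CCCCCCCCCCc1ccc(-c2noc([C@H]3CCCN3)n2)cc1` carries pyrrolidin-2-yl and gives 12%, the lowest of the three numbers; the steps leading to it are a number 14 percentage points lower from compound 2 to compound 3 (beyond the scatter) and a number 50 percentage points lower from compound 1 to compound 3 (beyond the scatter).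

Compound 4 `CCCCCCCCCCc1ccc(-c2noc(CC[C@@H](N)C(=O)O)n2)cc1` has not yet been measured. Its change from compound 3 is 3-amino-3-carboxypropyl in place of pyrrolidin-2-yl on an aromatic carbon. Among the compounds with values here, two measured steps bear on this: both replaced the aminomethyl of compound 1 with a five-membered ring, and both lowered the number, by a number 36 percentage points lower from compound 1 to compound 2 (beyond the scatter) and by a number 50 percentage points lower from compound 1 to compound 3 (beyond the scatter). Within the data shown here, compound 4 goes the other way, opening the ring back into a chain that carries an amine, as in compound 1, though the chain is longer and also bears a carboxy group, for which no measured compound gives guidance. A rise beyond the scatter is therefore expected, a number 28 percentage points higher from compound 3 to compound 4 (beyond the scatter), while stopping short of a full return to the number of compound 1. Compound 4 is estimated to give 40%, with a likely range from 15% to 65%.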

Compound 4, a percentage reported as inhibition, at one concentration (the size of the read-out at that concentration, not a potency): 5%
Beside the measured number, compound 4's estimate is 35 percentage points above it; measured number outside the range, below it.
By their numbers in this assay, from the lowest: compounds 4 and 3 (each within the scatter of the next); then compound 2; then compound 1.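

In this assay, opening the ring of pyrrolidin-2-yl into the 3-amino-3-carboxypropyl chain does not bring back the high number of the aminomethyl group: the step reads a number 7 percentage points lower from compound 3 to compound 4 (within the scatter), so this change cannot be told apart from no change. An open chain carrying an amine is therefore not enough at this position, as the steps of a number 57 percentage points lower from compound 1 to compound 4 (beyond the scatter) and a number 21 percentage points lower from compound 2 to compound 4 (beyond the scatter) show, the second of these setting the chain under even the pyrrolidin-3-yl ring. Among these compounds, both rings and this amino acid chain all fall well short of the small aminomethyl group, and nothing available explains why.

Compound 4 differs from compound 1 in two ways at once, a longer chain and an added carboxylic acid, so the compounds shown cannot say which of the two accounts for the step. A plain 2-aminoethyl or 3-aminopropyl chain with no carboxylic acid, or a short chain bearing a carboxylic acid with no amine, would pull these two apart.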